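Working notes on compound 1 and three ring-linked analogues

The source may report more compounds than this note shows. Statements on the series, on what has been measured and on what is new or still open speak of the compounds shown alone.

compound 1 `COCCNC(=O)CNc1ncc2c(Br)nn(-c3ccc4ncccc4c3)c2n1`: "nd" (no result reported)
compound 2 `COCCNC(=O)[C@H]1CC[C@@H](Nc2ncc3c(Br)nn(-c4ccc5ncccc5c4)c3n2)C1`: 156 nM
compound 3 `COCCNC(=O)[C@H]1CC[C@H](Nc2ncc3c(Br)nn(-c4ccc5ncccc5c4)c3n2)CC1`: 628 nM

Compound 1 stands without a single number in an assay on SK-OV-3 cells for inhibition of eIF-2-alpha kinase GCN2 (Homo sapiens); on this read-out higher numbers stand for weaker inhibition and lower numbers for stronger inhibition; no result was reported for it. Of the two measured cyclic analogues, compound 2 gives 156 nM and compound 3 gives 628 nM in this assay.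

Compound 4 `CS(=O)(=O)N1CC[C@@H](Nc2ncc3c(Br)nn(-c4ccc5ncccc5c4)c3n2)C1` arises from compound 1 by 1-(methylsulfonyl)pyrrolidin-3-yl in place of ((2-methoxyethyl)carbamoyl)methyl on a nitrogen on an aromatic ring. Since compound 1 has no value in this assay, neither the size nor the direction of the step to compound 4 can be set from compound 1 itself; the expectation rests on compound 2 and compound 3. Compound 4 is estimated at 300 nM, within 60 nM to 1500 nM, because compound 2 gives 156 nM and compound 3 gives 628 nM as the nearest ring-linked comparators.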

Compound 4, half-maximal inhibitory concentration: 378 nM
For compound 4 the middle estimate is 1.3-fold (0.10 log units) below the measured one, within the range that was stated.
By their numbers in this assay, from the lowest: compound 2; then compounds 4 and 3 (each within the scatter of the next).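

Among these compounds, with compound 1 at "nd" (no result reported) in this assay no step to compound 4 can be read. The compounds shown leave open how the ((2-methoxyethyl)carbamoyl)methyl and 1-(methylsulfonyl)pyrrolidin-3-yl groups compare on the shared core. No evidence bears on this result.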